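Compound 4: a 3-Hydroxy-4-methoxyphenyl Replacement

This account rests on a few compounds, and the source may have more. Where it says the series, first, only, none or still open, it means among the compounds named here.

Compound 3 `COc1cccc(C2C=C(c3cc(OC)c(OC)c(OC)c3)NC(=S)N2)c1` was tested in a functional assay on B16 cells (Mus musculus) for cytotoxicity, read by MTT assay, with a stated time of 72 h (a lower number here means a stronger inhibitor, a higher number a weaker inhibitor), where compound 3 gives 59500 nM. Compound 2 `COc1ccc(OC)c(C2C=C(c3cc(OC)c(OC)c(OC)c3)NC(=S)N2)c1` gives 36000 nM in this assay, and the step of a 1.7-fold higher number from compound 2 to compound 3 (0.22 log units; within the scatter) lies within the usual scatter, so the two sit together on the numbers shown. Compound 1 `COc1ccc(C2C=C(c3cc(OC)c(OC)c(OC)c3)NC(=S)N2)cc1OC` reaches only the limit of the assay, > 100000 nM in this assay, and this is a limit rather than a number (the limit of > 100000 nM in this assay, at which 1 of the 3 values shown sits). Compound 3 therefore stands as one of two numbers that do not separate from each other, with the third entry being a limit.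

Compound 4 `COc1ccc(C2C=C(c3cc(OC)c(OC)c(OC)c3)NC(=S)N2)cc1O` differs from compound 3 by 3-hydroxy-4-methoxyphenyl in place of 3-methoxyphenyl on a saturated ring carbon. Two measured steps involve the same aromatic ring: the step of an at least 1.6-fold lower number from compound 1 to compound 3 (0.22 log units; that floor lies within the scatter) and the step of a 1.7-fold higher number from compound 2 to compound 3 (0.22 log units; within the scatter). Both concern a methoxy exchanged for hydrogen, and neither adds a hydroxy group, so they give no direct guide to the entering 3-hydroxy-4-methoxyphenyl; both are also small. Compound 4 is accordingly expected to sit near compound 3, with the step of a 1.0-fold higher number from compound 3 to compound 4 (0.00 log units; within the scatter) estimated to stay within the scatter. For compound 4 in this assay the estimate is 60000 nM, between 25000 nM and 150000 nM.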

Compound 4, half-maximal inhibitory concentration: 6000 nM
The estimate for compound 4 lay 10-fold (1.00 log units) above the measured number; measured number below the stated range.
By their numbers in this assay, from the lowest: compound 4; then compounds 2 and 3 (each within the scatter of the next). At a limit, above all of these: compound 1.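

In this assay, for the compounds shown here, the step of a 9.9-fold lower number from compound 3 to compound 4 (1.00 log units; beyond the scatter) is the first change to the aromatic ring on the saturated ring carbon that lies beyond the scatter, whereas the earlier steps on this ring, which exchanged methoxy for hydrogen, stayed within it or had a floor within it. The step of an at least 16-fold lower number from compound 1 to compound 4 (1.22 log units; beyond the scatter) sharpens this, since compounds 1 and 4 differ only by hydrogen in place of methyl on an oxygen on an aromatic ring, and the entry for compound 1 is a limit, not a number. The gain therefore goes with the free hydroxy of 3-hydroxy-4-methoxyphenyl rather than with the number of oxygen substituents on the ring, although nothing shown gives a measured reason for it.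

As far as these compounds go, whether an amine or a carboxylic acid in place of that hydroxy would keep a number like that of compound 4 remains open. Also open, from the compounds shown here alone, are whether 3-hydroxyphenyl without the methoxy would do the same, and whether the gain would carry over to cells other than those of this one assay.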